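Benzyl in place of ethyl on compound 3

The source may hold more compounds than are shown below. What is called first, only, known or untested is meant among the compounds shown, and "the series" means these compounds.

Of the compounds shown here, three sharing one core have been tested in a functional assay on WiDr cells (Homo sapiens) for antiproliferative activity; a lower number here means a stronger inhibitor of growth, a higher number a weaker inhibitor of growth. Compound 1 `CC(C)CC1OCCC(Cl)=C1[Si](C)(C)C` gives 20000 nM, and compound 3 `CC[C@H]1CC(Cl)=C([Si](C)(C)C)[C@@H](C2CCCCC2)O1` gives 29000 nM; these two numbers lie within the usual scatter of each other, so compound 3 stands level with compound 1 rather than apart from it. For compound 2 `CCC(C)[C@H]1O[C@@H](C)CC(Cl)=C1[Si](C)(C)C` the result is only a limit, (the limit of > 100000 nM in this assay, at which 1 of the 3 values shown sits), reported as > 100000 nM. Compound 4 `C[Si](C)(C)C1=C(Cl)C[C@H](Cc2ccccc2)O[C@@H]1C1CCCCC1` has not been measured; it differs from compound 3 by phenyl in place of methyl on a saturated chain carbon bound to a saturated ring carbon. No comparable change has been measured within this set, so only a small step is expected, with the number falling modestly if at all, as expressed by a 1.9-fold lower number from compound 3 to compound 4 (0.29 log units; within the scatter). Compound 4 is therefore estimated at 15000 nM, expected to lie between 4000 nM and 60000 nM.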

Compound 4, concentration for 50% growth inhibition: 62000 nM
Estimate against measurement, compound 4: 4.1-fold (0.62 log units) below; measured number above the stated range.
By their numbers in this assay, from the lowest: compounds 1 and 3 (each within the scatter of the next); then compound 4. At a limit, above all of these: compound 2.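

Ethyl to benzyl, the first single-place change that can be read in this set, gives a 2.1-fold higher number from compound 3 to compound 4 (0.33 log units; beyond the scatter) in this assay. Adding phenyl on a saturated chain carbon bound to a saturated ring carbon therefore weakens growth inhibition here, though only modestly. No available evidence accounts for this rise.

As far as these compounds go, whether an amine or a hydroxyl group in place of phenyl would lower the number remains open. So does whether a longer chain carrying phenyl would move it further.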